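This account rests on a few compounds, and the source may have more. Where it says the series, first, only, none or still open, it means among the compounds named here.

Measured so far:
compound 1, `Oc1ccccc1NC(=S)Nc1ccc2[nH]ccc2c1` — 14000 nM
compound 2, `Oc1ccc(NC(=S)Nc2ccc3[nH]ccc3c2)cc1` — > 100000 nM

The two measured compounds are thiourea analogues on a shared indole-bearing core, differing only in where the hydroxy group sits on the phenyl ring. In an ADME assay on cells for inhibition of Amine oxidase [flavin-containing] A (Homo sapiens), read by spectrophotometry (a higher number here means a weaker inhibitor, a lower number a stronger inhibitor), compound 1 gives 14000 nM. For compound 2 this assay returns only a limit, > 100000 nM, so its place on the scale is not a number but a bound; the limit of > 100000 nM in this assay, at which 1 of the 2 values shown sits, marks where that limit sits among the two values shown. For the measured compounds named here, no step between measured compounds can be sized here.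

The next compound, compound 3, `S=C(Nc1ccc(Br)cc1)Nc1ccc2[nH]ccc2c1`, differs from compound 2 by bromo in place of hydroxy on an aromatic carbon, set on an aromatic carbon of a six-membered aromatic ring of carbon only, para to a large group. Since compound 2 stands only at a limit, the step of an at least 2.8-fold lower number from compound 2 to compound 3 (0.45 log units; beyond the scatter) is an expectation that the change brings the value back to a measurable number, and it may still fall near the limit. Compound 3 is accordingly estimated at 35000 nM in this assay, with a range from 6000 nM to 150000 nM.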

Compound 3, half-maximal inhibitory concentration: 23000 nM
Compound 3: middle estimate off by 1.5-fold (0.18 log units), on the high side, within the range that was stated.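

In this assay, bromo in place of hydroxy on an aromatic carbon, para to a large group, gives an at least 4.3-fold lower number from compound 2 to compound 3 (0.63 log units; beyond the scatter), so this position can carry a group that brings the read-out back to a measurable number, and the change is large enough to lie beyond the scatter. Compound 2 stands only at a limit, > 100000 nM. The step is therefore a minimum size and not a measured gap, because one end of it rests on that limit: the limit of > 100000 nM in this assay, at which 1 of the 3 values shown sits.

A single swap cannot separate the loss of the hydrogen-bond donor and acceptor that leave with hydroxy from the arrival of bromine itself, and chloro, methoxy or an amine at the same position would bear on that question. Also open, as far as these compounds go, are how bromo behaves at the position that carries hydroxy in compound 1, and whether the trend holds when the thiourea link gives way to a urea.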